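The source may hold more compounds than are shown below. What is called first, only, known or untested is meant among the compounds shown, and "the series" means these compounds.

Measured so far in a functional assay on MCF7 cells (Homo sapiens) for antiproliferative activity, read by sulforhodamine B assay, with a stated time of 3 days (on this read-out lower numbers stand for an effect already at smaller amounts and higher numbers for an effect only at larger amounts of compound), as follows:
- compound 1 `CCCC1=C(OC)C(CCC)(CCC)C(=O)/C(=C(O)\C=C\c2ccc(I)cc2)C1=O` gives 1.8 uM
- compound 2 `CCCC1=C(OCC(C)C)C(CCC)(CCC)C(=O)/C(=C(O)\C=C\c2ccccc2)C1=O` gives 4.4 uM
- compound 3 `CCCOC1=C(CCC)C(=O)/C(=C(O)/C=C/c2ccccc2)C(=O)C1(CCC)CCC` gives 1.6 uM

Compound 3 (1.6 uM) lies within the scatter of compound 1 (1.8 uM). It is reached by a 2.8-fold lower number from compound 2 to compound 3 (0.44 log units; beyond the scatter) and that change sits on a saturated chain, so it says little about the aromatic ring. Compound 4 `CCCOC1=C(CCC)C(=O)/C(=C(O)/C=C/c2ccc(I)cc2)C(=O)C1(CCC)CCC` carries iodo in place of hydrogen on an aromatic carbon. Among the compounds with values here, no measured step isolates this change. Compound 1 already holds the iodo group together with a different chain on oxygen and gives 1.8 uM in this assay, so no step beyond the scatter is expected. As far as these compounds go, the expected change is a 1.1-fold lower number from compound 3 to compound 4 (0.06 log units; within the scatter) and its direction stays open. For compound 4 the estimated value is 1.4 uM (range 0.6 uM to 3.2 uM).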

Compound 4, concentration for half-maximal effect: 5.1 uM
Compound 4: the middle estimate sits 3.6-fold (0.56 log units) below what was measured, outside the stated range (above it).
By their numbers in this assay, from the lowest: compounds 3 and 1 (each within the scatter of the next); then compounds 2 and 4 (each within the scatter of the next).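

On the propyl-ether scaffold, iodo at this aromatic carbon is not neutral: in this assay there is a 3.2-fold higher number from compound 3 to compound 4 (0.50 log units; beyond the scatter). With iodo held in place, the chain on oxygen also counts, with a 2.8-fold higher number from compound 1 to compound 4 (0.45 log units; beyond the scatter), so the closeness of compound 1 to compound 3 gave no reading of the iodo change alone. No measured data on the series explain either step.

Open, as far as these compounds go, is whether a smaller halogen such as chloro, or an amine, on the same aromatic carbon gives a step like that of iodo. Also open, from the compounds shown here alone, is whether a longer chain on oxygen moves the number further when iodo is present.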